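This account rests on a few compounds, and the source may have more. Where it says the series, first, only, none or still open, it means among the compounds named here.

In a functional assay on NCI-H1975 cells (Homo sapiens) for antiproliferative activity, read by MTT assay, with a stated time of 72 h (a lower number here means a stronger inhibitor, a higher number a weaker inhibitor), three compounds built on a shared core have been measured. Compound 1 `COc1cc(F)c(NC(=O)c2ccncc2OC)cc1Nc1nccc(-c2cn(C)c3ccccc23)n1` gives 4120 nM, and compound 2 `COc1cc(N(C)CCN(C)C)c(NC(=O)c2cccnc2)cc1Nc1nccc(-c2cn(C)c3ccccc23)n1` gives 1750 nM. Compound 3 `COc1cc(N(C)C)c(NC(=O)c2ccncc2OC)cc1Nc1nccc(-c2cn(C)c3ccccc23)n1` gives 12100 nM, the highest number of the three. Compound 4 `COc1cc(N(C)C)c(NC(=O)c2nccn2C)cc1Nc1nccc(-c2cn(C)c3ccccc23)n1` has not yet been measured. It differs from compound 3 by one change: 1-methyl-1H-imidazol-2-yl in place of 3-methoxypyridin-4-yl on a carbonyl carbon. In short, 1-methyl-1H-imidazol-2-yl stands in place of 3-methoxypyridin-4-yl on a carbonyl carbon. Among the compounds with values here, the only measured step, a 2.9-fold higher number from compound 1 to compound 3 (0.47 log units; beyond the scatter), is modest, but it swaps dimethylamino for fluoro on an aromatic carbon, so no measured step tests the new change directly. Compound 2 differs from compound 3 in more than one place and cannot isolate it either. With compound 3 at 12100 nM at the top of this small range, a modest move to a lower number is expected in this assay, with wide uncertainty. The expected step is a 2.2-fold lower number from compound 3 to compound 4 (0.34 log units; beyond the scatter). Compound 4 is estimated at 5500 nM, with an expected range from 1500 nM to 18000 nM.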

Compound 4, half-maximal inhibitory concentration: 2880 nM
The estimate for compound 4 lay 1.9-fold (0.28 log units) above the measured number, and the stated range covers the measured number.
By their numbers in this assay, from the lowest: compounds 2, 4 and 1 (each within the scatter of the next, the first and the last beyond it); then compound 3.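

In this assay, the change to 1-methyl-1H-imidazol-2-yl in place of 3-methoxypyridin-4-yl on a carbonyl carbon gives a 4.2-fold lower number from compound 3 to compound 4 (0.62 log units; beyond the scatter). Within the data shown here, the earlier step, a 2.9-fold higher number from compound 1 to compound 3 (0.47 log units; beyond the scatter), concerned dimethylamino and fluoro on an aromatic carbon, so this is the only reading here showing that the group on the carbonyl carbon alone can shift the number beyond the scatter. Nothing measured here bears on what lies behind this shift.

Still open, on these data alone, is whether the shift depends on the imidazole ring itself or on its methyl group, which a plain imidazol-2-yl or a phenyl ring on the same carbonyl carbon would help to separate. Also open, as far as these compounds go, is whether the step carries over when fluoro stands in place of dimethylamino.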